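A few compounds are considered here, and "the series" means these few. Any claim that something is new, unique, unknown or untested is made for them only; others in the source may bear on it.

Compound 1 `Cc1ccnc(/C(N)=N/NC(=S)N2CCSCC2)c1` is the starting point of this account. For the measured compounds named here, in a functional assay on A-431 cells (Homo sapiens) for cytotoxicity, read by MTT assay, with a stated time of 72 h, tested at 1 uM (on this read-out lower numbers stand for less inhibition of growth and higher numbers for more inhibition of growth at the one concentration tested), compound 1 gives 34.6%, which places it second highest of the three numbers measured so far. Its nearest neighbour is compound 2 `N/C(=N\NC(=S)N1CCSCC1)c1ccccn1`, which in this assay gives 31.7%, and the shift a number 2.9 percentage points lower from compound 1 to compound 2 (within the scatter) stays within the scatter; the change there is hydrogen in place of methyl on an aromatic carbon. The furthest is compound 3 `N/C(=N\NC(=S)N1CCSCC1)c1ccc(F)cn1`, which in this assay gives 48.7%; the shift a number 17 percentage points higher from compound 2 to compound 3 (beyond the scatter) comes from fluoro in place of hydrogen on an aromatic carbon.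

Compound 4 `Cc1ccnc(/C(N)=N/NC(=S)N2CCCCC2)c1` has not yet been measured. It differs from compound 1 by piperidin-1-yl in place of thiomorpholin-4-yl on a thiocarbonyl carbon. Neither of the two measured steps touches this part of the shared core: both alter substituents on the aromatic ring, while the change to compound 4 exchanges the ring attached to the thiocarbonyl carbon. Going by the values given here, there is therefore no measured step that bears on it, and the account expects no shift beyond the scatter in this assay, in either direction, when going from compound 1 to compound 4, so that the step is estimated at a number 0.4 percentage points higher from compound 1 to compound 4 (within the scatter). On that basis compound 4 is expected to give about 35% in this assay, within a range from 15% to 55%.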

Compound 4, percent growth inhibition at one concentration: 31.1%
Beside the measured number, compound 4's estimate is 3.9 percentage points above it, and the stated range covers the measured number.
By their numbers in this assay, from the lowest: compounds 4, 2 and 1 (each within the scatter of the next); then compound 3.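

For the compounds shown here, the step on the thiocarbonyl carbon is the first look at this part of the molecule, since the earlier steps changed only substituents on an aromatic carbon. In this assay the result is a number 3.5 percentage points lower from compound 1 to compound 4 (within the scatter) and so, at the one concentration tested, piperidin-1-yl cannot be told apart from thiomorpholin-4-yl, even though the exchange takes out the ring sulfur and the hydrogen-bond acceptor counted for that group. This position has so far shown nothing like the one step beyond the scatter, a number 17 percentage points higher from compound 2 to compound 3 (beyond the scatter), which remains confined to the aromatic carbon. Nothing available on these compounds gives any account of why the two rings read alike.

The compounds shown leave open how a morpholin-4-yl or 4-methylpiperazin-1-yl ring, or an open-chain dimethylamino group, would read on the same thiocarbonyl carbon. They also leave open whether the gain seen with fluoro in place of hydrogen on an aromatic carbon would carry over to a compound that bears piperidin-1-yl on the thiocarbonyl carbon.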